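A few compounds are considered here, and "the series" means these few. Any claim that something is new, unique, unknown or untested is made for them only; others in the source may bear on it.

In a functional assay on HCT-116 cells (Homo sapiens) for inhibition, read by MTT assay, with a stated time of 48 h (on this read-out lower numbers stand for stronger inhibition and higher numbers for weaker inhibition), compound 3 `COc1ccc(N(C)c2nc(C)nc3ccccc23)cc1[Se]C` gives 28 nM, the lowest of the three measured numbers. Compound 1 `COc1ccc(N(C)c2nc(C)nc3ccccc23)cc1OCCCCCC[Se]C#N` gives 6180 nM, and compound 2 `COc1ccc(N(C)c2nc(C)nc3ccccc23)cc1C(=O)OCCC[Se]C#N` gives 720 nM. Compound 4 `COc1ccc(N(C)c2nc(C)nc3ccccc23)cc1OCCCC[Se]C#N` differs from compound 3 by a group of 8 heavy atoms (5 carbon, 1 nitrogen, 1 oxygen, 1 selenium; no ring) in place of a group of 2 heavy atoms (1 carbon, 1 selenium; no ring), on an aromatic carbon. For the measured compounds named here, the steps that bear on this are a 220-fold lower number from compound 1 to compound 3 (2.34 log units; beyond the scatter) and a 26-fold lower number from compound 2 to compound 3 (1.41 log units; beyond the scatter), each large and beyond the scatter; both show that a long selenocyanate-bearing chain in place of the two-atom group on this aromatic carbon goes with a much higher number. Compound 4 carries such a chain, shorter than that of compound 1, so a large rise is expected, a 71-fold higher number from compound 3 to compound 4 (1.85 log units; beyond the scatter). Compound 4 is therefore estimated at 2000 nM, within 500 nM to 8000 nM.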

Compound 4, half-maximal inhibitory concentration: 512 nM
For compound 4 the middle estimate is 3.9-fold (0.59 log units) above the measured one; low and high end bracket the measured number.
By their numbers in this assay, from the lowest: compound 3; then compounds 4 and 2 (each within the scatter of the next); then compound 1.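

Shortening the selenocyanate chain on the oxygen alone gives a 12-fold lower number from compound 1 to compound 4 (1.08 log units; beyond the scatter), so the length of this chain matters at this position. The shorter chain still does not match the small group of compound 3, as an 18-fold higher number from compound 3 to compound 4 (1.26 log units; beyond the scatter) shows. In this assay, the chain of compound 4 and the carbonyl-linked chain of compound 2 cannot be told apart, with a 1.4-fold lower number from compound 2 to compound 4 (0.15 log units; within the scatter).

From the compounds shown here alone, whether a still shorter chain, or an amine in place of the selenocyanate end, would bring the number closer to that of compound 3 stays open. Nothing available here explains these differences.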